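Cyano for Fluoro on the Pendant Phenyl

The source may hold more compounds than are shown below. What is called first, only, known or untested is meant among the compounds shown, and "the series" means these compounds.

Measured compounds:
compound 1, `CC(C)c1ccc(-n2nc(-c3ccc(C(F)(F)F)cc3O)nc2-c2ccccc2O)cc1`, 108%
compound 2, `Oc1cc(C(F)(F)F)ccc1-c1nc(-c2ccccc2O)n(-c2ccc(F)cc2)n1`, 99.8%
compound 3, `Oc1cc(C(F)(F)F)ccc1-c1nc(-c2ccccc2O)n(-c2ccc(OC(F)(F)F)cc2)n1`, 92.5%

In a functional assay on PC-12 cells (Rattus norvegicus) for cytotoxicity, read by MTT assay, with stated times of 2 h and 24 h, tested at 10 uM (on this read-out lower numbers stand for a weaker effect and higher numbers for a stronger effect at the one concentration tested), compound 2 gives 99.8%, which stands between compound 1 and compound 3, both within the scatter of it. Compound 4, `N#Cc1ccc(-n2nc(-c3ccc(C(F)(F)F)cc3O)nc2-c2ccccc2O)cc1`, is not yet measured; it differs from compound 2 by cyano in place of fluoro on an aromatic carbon. Two measured steps change the same position: a number 8.2 percentage points lower from compound 1 to compound 2 (within the scatter) and a number 7.3 percentage points lower from compound 2 to compound 3 (within the scatter), both within the scatter; only a number 15.5 percentage points lower from compound 1 to compound 3 (beyond the scatter) reaches beyond it. Exchanges at this position have therefore produced little change in this assay, so no step beyond the scatter is expected for compound 4, and a step of a number 2.8 percentage points lower from compound 2 to compound 4 (within the scatter) is estimated. Compound 4 is expected to give 97%, in the range 82% to 112%.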

Compound 4, a percentage reported as activity, at one concentration (the size of the read-out at that concentration, not a potency): 98.9%
The estimate for compound 4 lay 1.9 percentage points below the measured number; low and high end bracket the measured number.
By their numbers in this assay, from the lowest: compounds 3, 4, 2 and 1 (each within the scatter of the next, the first and the last beyond it).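

In this assay, putting a nitrile at this position, with its triple bond and hydrogen-bond acceptor, gives a number 0.9 percentage points lower from compound 2 to compound 4 (within the scatter). The other two exchanges give a number 6.4 percentage points higher from compound 3 to compound 4 (within the scatter) and a number 9.1 percentage points lower from compound 1 to compound 4 (within the scatter), so compound 4 lies within the scatter of all three earlier compounds, even though compound 1 and compound 3 lie beyond the scatter of each other. Nothing available here gives a cause for this result. On these data alone, whether an amine, a carboxylic acid or a longer chain at this position would give a step beyond the scatter from compound 2 remains open.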